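The source may report more compounds than this note shows. Statements on the series, on what has been measured and on what is new or still open speak of the compounds shown alone.

Measured in a functional assay on SH-SY5Y cells (Homo sapiens) for antiproliferative activity, read by MTT assay, with a stated time of 48 h; a lower number here means a stronger inhibitor of growth, a higher number a weaker inhibitor of growth:
- compound 1 `COc1ccccc1OCCNc1ccc(=O)n(Cc2ccc(OC(F)F)c(OC3CCCC3)c2)n1`: 9300 nM
- compound 2 `COc1ccccc1OCCNc1ccc(=O)n(Cc2ccc(OC)c(OCC3CC3)c2)n1`: 10500 nM
- compound 3 `COc1ccc(Cn2nc(NCCOc3ccccc3OC)ccc2=O)cc1Br`: > 100000 nM (a limit)

Compound 2 gives 10500 nM and compound 1 gives 9300 nM, two values within the usual scatter of each other. The value of compound 3 is a limit of the assay, not a number.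

Compound 4 `COc1ccccc1OCCNc1ccc(=O)n(Cc2ccc(OC(F)F)c(OCC3CC3)c2)n1` derives from compound 2 through difluoromethyl in place of methyl on an oxygen on an aromatic ring. Going by the values given here, no measured step covers this exchange. Among the compounds with values here, the one measured step, bromo in place of cyclopropylmethoxy, is an at least 9.5-fold higher number from compound 2 to compound 3 (0.97 log units; beyond the scatter) and lies beyond the scatter, but compound 4 keeps the cyclopropylmethoxy, so that step bears on it only weakly. Closer evidence comes from compound 1, which also carries difluoromethoxy and gives 9300 nM. No step beyond the scatter is therefore expected in this assay, and the expected result is a 1.1-fold lower number from compound 2 to compound 4 (0.04 log units; within the scatter). For compound 4 the estimated value is 9500 nM, with an expected range of 4000 nM to 23000 nM.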

Compound 4, concentration for 50% growth inhibition: 6300 nM
Estimate against measurement, compound 4: 1.5-fold (0.18 log units) above; the range from low to high includes it.
By their numbers in this assay, from the lowest: compounds 4, 1 and 2 (each within the scatter of the next). At a limit, above all of these: compound 3.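

In this assay the change from methoxy to difluoromethoxy can now be read with the cyclopropylmethoxy kept: a 1.7-fold lower number from compound 2 to compound 4 (0.22 log units; within the scatter), so difluoromethyl in place of methyl on this oxygen leaves the level of growth inhibition within the scatter. With the difluoromethoxy kept, the neighbouring ether can also be read, with cyclopropylmethyl in place of cyclopentyl giving a 1.5-fold lower number from compound 1 to compound 4 (0.17 log units; within the scatter), again no separation. Nothing measured here bears on why these two steps are this small.

As far as these compounds go, whether trifluoromethyl, an amine-bearing chain or a longer chain on the same oxygen would hold this level remains open. From the compounds shown here alone, compound 3 gives > 100000 nM, which is a limit, and whether bromo has the same outcome with difluoromethoxy in place of methoxy also stays open.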